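A Chlorophenyl Swap on a Weak Growth Inhibitor

The compounds below may be only part of what the source reports. "The series", "measured", "known", "first", "only" and "open" are said of these compounds alone.

In a functional assay on DWD cells (Homo sapiens) for inhibition, read by sulforhodamine B assay (a lower number here means a stronger inhibitor of growth, a higher number a weaker inhibitor of growth), compound 3 `Oc1ccc(-c2ccc(-c3ccc(-c4nc5ccccc5[nH]4)cc3)cc2)cc1` gives 46300 nM and compound 2 `Fc1ccc(-c2ccc(-c3ccc(-c4nc5ccccc5[nH]4)cc3)cc2)cc1` gives 35600 nM. These two cannot be told apart: the change is a 1.3-fold higher number from compound 2 to compound 3 (0.11 log units; within the scatter). That single step shows that hydroxy and fluoro on this end ring give similar numbers, but it says nothing about a chlorophenyl group. Compound 1 `Cc1ccc2[nH]c(-c3ccc(-c4ccc(-c5cccc(Cl)c5)cc4)cc3)nc2c1` gives 2510 nM, well below both and beyond the scatter.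

Compound 4 `Clc1cccc(-c2ccc(-c3ccc(-c4nc5ccccc5[nH]4)cc3)cc2)c1` has 3-chlorophenyl in place of 4-hydroxyphenyl, on an aromatic carbon para to a large group: 3-chlorophenyl in place of 4-hydroxyphenyl on an aromatic carbon. Compound 1 carries the same 3-chlorophenyl group, but on a different core, so its 2510 nM points the direction without fixing the size. Only part of that gap is expected to carry over, which would mean a stronger inhibitor than compound 3. The expected change is a 5.1-fold lower number from compound 3 to compound 4 (0.71 log units; beyond the scatter). The estimate for compound 4 is 9000 nM, with an expected range from 2500 nM to 35000 nM.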

Compound 4, concentration for 50% growth inhibition: 100000 nM
Estimate against measurement, compound 4: 11-fold (1.05 log units) below; the measured number lies above the stated range.
By their numbers in this assay, from the lowest: compound 1; then compounds 2 and 3 (each within the scatter of the next); then compound 4.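

In this assay, 3-chlorophenyl at this position gives a weaker inhibitor of growth, not a stronger one, with modest steps from both neighbours (a 2.2-fold higher number from compound 3 to compound 4 (0.33 log units; beyond the scatter)) and (a 2.8-fold higher number from compound 2 to compound 4 (0.45 log units; beyond the scatter)). Among these compounds, the 3-chlorophenyl group alone therefore does not bring the strength of compound 1: with that group held fixed, the single change of hydrogen in place of methyl on an aromatic carbon of the core gives a large step (a 40-fold higher number from compound 1 to compound 4 (1.60 log units; beyond the scatter)). Nothing measured here gives a reason for these steps.

From the compounds shown here alone, it remains open whether the same methyl would also lower the number with 4-hydroxyphenyl or 4-fluorophenyl at this position. Going by these compounds, it is equally open how an amine or a carboxylic acid on this end ring would compare.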